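Nitropyridinyl piperidine alkynes at metabotropic glutamate receptor 5

The compounds below may be only part of what the source reports. "The series", "measured", "known", "first", "only" and "open" are said of these compounds alone.

In an assay on cells for displacement of a labelled ligand from metabotropic glutamate receptor 5 (Homo sapiens), read by scintillation counting, with a stated time of 60 min (on this read-out lower numbers stand for stronger inhibition and higher numbers for weaker inhibition), compound 1 `O=C(c1cnc2ccccc2n1)N1CCN(c2ncccc2[N+](=O)[O-])CC1` gives > 10000 nM, which is a limit of the assay and not a number. Compound 2 `O=[N+]([O-])c1cccnc1N1CCN(CC#Cc2ccccc2)CC1` gives 60.7 nM in this assay. Compound 3 `Cc1cccc(C#CC=C2CCN(c3ncccc3[N+](=O)[O-])CC2)n1` gives 0.5 nM in this assay, the lowest of the two numbers; its nearest neighbour is compound 2, and that gap lies beyond the scatter. Compound 4 `N#Cc1cc(Cl)cc(C#CC=C2CCN(c3ncccc3[N+](=O)[O-])CC2)c1` carries 3-chloro-5-cyanophenyl in place of 6-methylpyridin-2-yl on a triple-bonded carbon. Going by the values given here, no measured pair isolates this change, so its size rests on expectation alone; only a small step is expected, a 3.0-fold higher number from compound 3 to compound 4 (0.48 log units; beyond the scatter), toward a slightly higher number if any, since the alkyne-linked aryl piece is kept. Compound 4 is estimated at 1.5 nM in this assay, with a range from 0.3 nM to 10 nM.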

Compound 4, inhibition constant: 283 nM
Compound 4: the middle estimate sits 190-fold (2.28 log units) below what was measured; measured number outside the range, above it.
By their numbers in this assay, from the lowest: compound 3; then compound 2; then compound 4. At a limit, above all of these: compound 1.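

In this assay, going by these compounds alone, replacing the 6-methylpyridin-2-yl group with a 3-chloro-5-cyanophenyl group gives a 570-fold higher number from compound 3 to compound 4 (2.75 log units; beyond the scatter), the first step that isolates a single place. Keeping an aromatic ring at this position is therefore not enough to hold the low number; the outcome depends strongly on which ring sits there. Nothing measured here gives a cause for this step.

From the compounds shown here alone, it remains open which feature of either ring carries the difference. A pyridine ring without the methyl, or a benzene ring bearing only chlorine or only a nitrile, would begin to separate these contributions.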